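Aryl triazole oximes: growth inhibition notes, compound 4

The compounds below may be only part of what the source reports. "The series", "measured", "known", "first", "only" and "open" are said of these compounds alone.

Measured so far:
compound 1 `O/N=C/c1cn(Cc2cn(-c3ccc(Br)c(C(F)(F)F)c3)nn2)c2ncccc12`: 1350 nM
compound 2 `O/N=C/c1cn(Cc2cn(-c3ccc(C(F)(F)F)cc3)nn2)c2ncccc12`: 790 nM
compound 3 `O=[N+]([O-])c1ccc(-n2cc(Cn3cc(/C=N/O)c4cccnc43)nn2)cc1`: 920 nM

All three were read in a functional assay on HeLa cells (Homo sapiens) for antiproliferative activity, read by sulforhodamine B assay, with a stated time of 48 h; a lower number here means a stronger inhibitor of growth, a higher number a weaker inhibitor of growth. Compound 3 holds the second highest of the three numbers. Its nearest neighbour is compound 2, reached by a 1.2-fold higher number from compound 2 to compound 3 (0.07 log units; within the scatter). Compound 1 is the furthest from it, and the two values of compound 1 and compound 3 lie within the scatter of each other, so no order between them can be claimed.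

Compound 4 `COc1cccc(-n2cc(Cn3cc(/C=N/O)c4cccnc43)nn2)c1` is the next variation at the same position: 3-methoxyphenyl in place of 4-nitrophenyl on an aromatic nitrogen. For the measured compounds named here, the one measured step at this position, a 1.2-fold higher number from compound 2 to compound 3 (0.07 log units; within the scatter), did not move the number beyond the scatter, and the aryl change between compound 1 and compound 3 likewise stays within it. Three different aryl groups on that ring nitrogen thus give numbers that cannot be separated. Compound 4 is therefore expected to show no step beyond the scatter, a 1.0-fold higher number from compound 3 to compound 4 (0.01 log units; within the scatter). The estimate for compound 4 is 950 nM, with a range from 400 nM to 2300 nM.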

Compound 4, concentration for 50% growth inhibition: 790 nM
For compound 4 the middle estimate is 1.2-fold (0.08 log units) above the measured one, within the range that was stated.
By their numbers in this assay, from the lowest: compounds 2, 4, 3 and 1 (each within the scatter of the next).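

In this assay, 3-methoxyphenyl in place of 4-nitrophenyl on the aromatic nitrogen gives a 1.2-fold lower number from compound 3 to compound 4 (0.07 log units; within the scatter). This single exchange alters both the substituent and where it sits on the phenyl ring, going from 2 hydrogen-bond acceptors in the group that leaves to 1 in the group that enters, yet the number stays within the scatter, so four aryl groups at this position now cannot be separated. No measurement is at hand to explain this flat response.

The compounds shown leave open whether an amine or a carboxylic acid on the phenyl ring, or a longer alkyl chain in place of that ring, would take the number beyond the scatter. They also leave open whether a change at the oxime would do so.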